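The source may report more compounds than this note shows. Statements on the series, on what has been measured and on what is new or still open speak of the compounds shown alone.

Going by the values given here, compound 3 `CS(=O)(=O)Nc1cccc(-c2cc(C(O)(C(F)(F)F)C(F)(F)F)cnc2N2CCN(S(=O)(=O)c3ccc(N)nc3)CC2)c1` is the only member of this set with a numeric result in an ADME assay (liver) for metabolic stability, with Liver microsome (Homo sapiens) as the target, using microsomes and NADPH, with a stated time of 30 min, tested at 1 uM; a higher number here means faster removal of the compound, a lower number slower removal: compound 3 gives 40 mL.min-1.g-1. Compound 1 `Nc1ccc(S(=O)(=O)N2CCN(c3ncc(C(O)(C(F)(F)F)C(F)(F)F)cc3C#CCO)CC2)cn1` returns only a limit of the assay, < 14 mL.min-1.g-1. Compound 2 `Nc1ccc(S(=O)(=O)N2CCN(c3ncc(C(O)(C(F)(F)F)C(F)(F)F)cc3-c3ccoc3)CC2)cn1` likewise returns only a limit, < 14 mL.min-1.g-1. Two of the three results therefore sit at the limit of < 14 mL.min-1.g-1 in this assay, at which 2 of the 3 values shown sit. Compound 4 `Nc1ccc(S(=O)(=O)N2CCN(c3ncc(C(O)(C(F)(F)F)C(F)(F)F)cc3-c3cccc4[nH]ncc34)CC2)cn1` is not yet measured; it differs from compound 3 by 1H-indazol-4-yl in place of 3-(methanesulfonamido)phenyl on an aromatic carbon. Among the compounds with values here, the steps that bear on this change are an at least 2.8-fold higher number from compound 1 to compound 3 (0.45 log units; beyond the scatter) and an at least 2.8-fold higher number from compound 2 to compound 3 (0.45 log units; beyond the scatter), both at least modest rises on introducing the 3-(methanesulfonamido)phenyl group. Since compound 4 replaces that group with 1H-indazol-4-yl, the expected step is a 1.6-fold lower number from compound 3 to compound 4 (0.20 log units; within the scatter), a partial return toward the lower readings. For compound 4 the estimate in this assay is 25 mL.min-1.g-1, between 10 mL.min-1.g-1 and 60 mL.min-1.g-1.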

Compound 4, intrinsic clearance in microsomes: 42 mL.min-1.g-1
Estimate against measurement, compound 4: 1.7-fold (0.23 log units) below; the range from low to high includes it.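

In this assay, the higher reading at this position is not tied to 3-(methanesulfonamido)phenyl, as 1H-indazol-4-yl also gives an at least 3.0-fold higher number from compound 2 to compound 4 (0.47 log units; beyond the scatter) and an at least 3.0-fold higher number from compound 1 to compound 4 (0.47 log units; beyond the scatter). Exchanging one group for the other leaves the reading flat, with a 1.1-fold higher number from compound 3 to compound 4 (0.02 log units; within the scatter). Both groups hold a six-membered aromatic ring of carbon only, which furan-3-yl and 3-hydroxyprop-1-yn-1-yl lack, though four compounds cannot show that this ring matters.

On these data alone, the full size of both rises remains open, with the lower readings being limits of the assay: the limit of < 14 mL.min-1.g-1 in this assay, at which 2 of the 4 values shown sit. Whether an unsubstituted phenyl, or a phenyl carrying an amine or a carboxylic acid, stays at the higher reading is also open.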